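The source may report more compounds than this note shows. Statements on the series, on what has been measured and on what is new or still open speak of the compounds shown alone.

Measured so far:
compound 1, `O=C(O)/C=C/c1cc(O)c(O)c(O)c1`, gives 131000 nM in a functional assay on C2BBe1 cells (Homo sapiens) for cytotoxicity, read by sulforhodamine B assay, with a stated time of 24 h; a higher number here means a weaker inhibitor, a lower number a stronger inhibitor;
compound 2, `CCCCCCNC(=O)/C=C/c1ccc(O)c(O)c1`, gives 37300 nM in this assay.

Of the two numbers, compound 2 holds the lower one, and the number of compound 1 lies higher by a margin beyond the usual scatter. Going by the values given here, the two compounds differ in more than one place, so no single step between them is recorded, and their two values are all that can be said of the pair.

The account turns to compound 3, `CCCCCCNC(=O)/C=C/c1cc(O)c(O)c(O)c1`, which has not yet been measured in this assay. Compound 3 differs from compound 2 by hydroxy in place of hydrogen on an aromatic carbon. Among the compounds with values here, no measured pair shows the effect of this change alone.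

With nothing in the data to anchor the direction, compound 3 is expected to land close to compound 2, with a step of a 1.2-fold lower number from compound 2 to compound 3 (0.09 log units; within the scatter) that is estimated to stay within the scatter. The value of compound 3 in this assay is therefore estimated at 30000 nM, with a range from 12000 nM to 80000 nM.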

Compound 3, half-maximal inhibitory concentration: 115000 nM
The estimate for compound 3 lay 3.8-fold (0.58 log units) below the measured number; measured number above the stated range.
By their numbers in this assay, from the lowest: compound 2; then compounds 3 and 1 (each within the scatter of the next).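

Going by these compounds alone, this step is the first measured view of this change alone: on the core of compound 2, hydroxy in place of hydrogen on an aromatic carbon, ortho to a hydroxy group and meta to a hydroxy group, gives a 3.1-fold higher number from compound 2 to compound 3 (0.49 log units; beyond the scatter) in this assay, so this position does not accept the added group without a loss, though the step is a modest one. With the new number, compound 3 at 115000 nM and compound 1 at 131000 nM stand within the scatter of each other, and compound 2 alone holds a number set apart from both by more than the scatter. Nothing measured alongside these numbers accounts for the step.

The compounds shown leave open whether the same step would appear on the core of compound 1, which carries a carboxylic acid, or with a longer chain on the amide nitrogen. They also leave open whether a methoxy group or a fluorine atom at this position would give a step like that of hydroxy.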